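Cytotoxicity notes on a naphthyl ketone sulfonamide series

This account rests on a few compounds, and the source may have more. Where it says the series, first, only, none or still open, it means among the compounds named here.

Two members of the series have been measured for cytotoxicity in an ADME assay on C8166 cells (Homo sapiens) for cytotoxicity, read by colorimetric assay and MTT assay; on this read-out higher numbers stand for lower toxicity in this test and lower numbers for higher toxicity in this test. Compound 1 `Cc1ccc(C(=O)c2c(OCC(=O)Nc3ccc(S(N)(=O)=O)cc3C)ccc3ccccc23)cc1C` carries a dimethylphenyl ketone on the shared core; in this assay compound 1 gives 33000 nM. Compound 2 `Cc1cc(S(N)(=O)=O)ccc1NC(=O)COc1ccc2cc(Br)ccc2c1C(=O)c1cccc(F)c1` carries a fluorophenyl ketone and a bromine on the core; in this assay compound 2 gives 31000 nM. Compound 2 has the lower of the two numbers, but its nearest neighbour, compound 1, sits within the scatter of it, so the two readings cannot be told apart.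

Compound 3 `Cc1ccc(C(=O)c2c(OCC(=O)Nc3ccc(S(N)(=O)=O)cc3C)ccc3cc(Br)ccc23)cc1C` has not yet been measured. It differs from compound 2 by 3,4-dimethylphenyl in place of 3-fluorophenyl on a carbonyl carbon, and thus joins the ketone substituent of compound 1 to the brominated core of compound 2. The same ketone substituent in compound 1 gave a number indistinguishable from that of compound 2, so no step beyond the scatter is expected in either direction in this assay.

For compound 3 the expected value in this assay is 31000 nM, with a range from 15000 nM to 62000 nM, and the estimated step is no change at the digits printed from compound 2 to compound 3 (within the scatter).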

Compound 3, half-maximal cytotoxic concentration: 85200 nM
Estimate against measurement, compound 3: 2.7-fold (0.44 log units) below; measured number outside the range, above it.
By their numbers in this assay, from the lowest: compounds 2 and 1 (each within the scatter of the next); then compound 3.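

In this assay the substituent on the carbonyl carbon matters on the brominated core: 3,4-dimethylphenyl in place of 3-fluorophenyl brings a 2.7-fold higher number from compound 2 to compound 3 (0.44 log units; beyond the scatter), which on this read-out points to lower toxicity in this test. With the 3,4-dimethylphenyl ketone held constant, bromo in place of hydrogen on an aromatic carbon brings a 2.6-fold higher number from compound 1 to compound 3 (0.41 log units; beyond the scatter), so both single changes move the number in the same direction, a reading unavailable from compounds 1 and 2 alone, as they differ in two places. No measurement at hand accounts for either step.

The compounds shown leave open whether the ketone step carries over to the core without bromine, and whether the bromo step carries over to a 3-fluorophenyl ketone, since neither has a matching pair here. Also open, from the compounds shown here alone, is how the number would respond to a chloro group in place of the bromo, or to an amine or a carboxylic acid on the aromatic ring of the ketone.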